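Swapping Ethyl for Trifluoromethyl at the Edge of Detection

A few compounds are considered here, and "the series" means these few. Any claim that something is new, unique, unknown or untested is made for them only; others in the source may bear on it.

Three compounds share one core and differ only in a single group on an aromatic carbon. Compound 1 `C=Cc1ccc(S(=O)(=O)Nc2ccc(-c3nc4ccccc4o3)cc2)cc1` carries a vinyl group, compound 2 `O=S(=O)(Nc1ccc(-c2nc3ccccc3o2)cc1)c1ccc(O)cc1` a hydroxy group, and compound 3 `CCc1ccc(S(=O)(=O)Nc2ccc(-c3nc4ccccc4o3)cc2)cc1` an ethyl group. In an assay on cells for inhibition of HSP60/HSP10 (Homo sapiens), with a stated time of 60 min (on this read-out higher numbers stand for weaker inhibition and lower numbers for stronger inhibition), compound 2 gives 78000 nM. For compound 1 this assay reports only a limit, > 100000 nM. For compound 3 this assay likewise reports only a limit, > 100000 nM. Because two of the three values sit at the limit of > 100000 nM in this assay, at which 2 of the 3 values shown sit, the steps read as an at least 1.2-fold lower number from compound 1 to compound 2 (0.10 log units; that floor lies within the scatter), as a step that the two limits leave unreadable from compound 1 to compound 3, and as an at least 1.2-fold higher number from compound 2 to compound 3 (0.10 log units; that floor lies within the scatter). Among the compounds with values here, compound 3 therefore stands at the limit, beside compound 1, with compound 2 the only member giving a number.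

Compound 4 `O=S(=O)(Nc1ccc(-c2nc3ccccc3o2)cc1)c1ccc(C(F)(F)F)cc1` introduces (trifluoromethyl in place of ethyl on an aromatic carbon). Within the data shown here, the two steps that reach compound 3 both end at a limit, so neither gives a readable size, and no measured step involves a trifluoromethyl group. The expectation is therefore no change beyond the scatter, with a number no higher from compound 3 to compound 4 (the limit leaves the size open) as the estimated step. Compound 4 is expected to give 100000 nM in this assay, within a range from 40000 nM to 300000 nM, most likely again as a limit.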

Compound 4, half-maximal inhibitory concentration: 50000 nM
For compound 4 the middle estimate is 2.0-fold (0.30 log units) above the measured one; the range from low to high includes it.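

With trifluoromethyl on this aromatic carbon, para to a large group, compound 4 gives the series a second measured number in this assay, where hydroxy in compound 2 had given the only one so far. The comparison with hydroxy reads as a 1.6-fold lower number from compound 2 to compound 4 (0.19 log units; within the scatter), so these two groups cannot be told apart on this read-out. The comparisons with ethyl and vinyl read as an at least 2.0-fold lower number from compound 3 to compound 4 (0.30 log units; that floor lies within the scatter) and as an at least 2.0-fold lower number from compound 1 to compound 4 (0.30 log units; that floor lies within the scatter), and both are only floors, with their true sizes hidden because of this: the limit of > 100000 nM in this assay, at which 2 of the 4 values shown sit.

Still open, as far as these compounds go, is whether any group at this position can move the number well beyond the scatter, as an amine, a carboxylic acid or a longer chain such as propyl might or might not do. Also open, from the compounds shown here alone, is how far compound 1 and compound 3 really lie from compound 4, and whether trifluoromethyl would give a similar number elsewhere on the same ring.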